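A few compounds are considered here, and "the series" means these few. Any claim that something is new, unique, unknown or untested is made for them only; others in the source may bear on it.

In a functional assay on MDA-MB-231 cells (Homo sapiens) for cytotoxicity, read by MTT assay, with a stated time of 48 h (a higher number here means a weaker inhibitor, a lower number a stronger inhibitor), compound 1 `O=C(OCCCC(c1ccc(F)cc1)c1ccc(F)cc1)c1cc(Cl)c(OCc2ccccc2)c(Cl)c1` gives > 20000 nM as a limit of the assay, not a number. Compound 3 `Cc1ccc(NC(=O)NCCCCC(c2ccc(F)cc2)c2ccc(F)cc2)cc1` also gives > 20000 nM as a limit of the assay, not a number. Among the measured compounds shown here, compound 2 `O=C(NCCCCC(c1ccc(F)cc1)c1ccc(F)cc1)Nc1ccc(I)cc1` gives 11800 nM and is the only compound in the set with a true number. The rest of the set stands at a limit (the limit of > 20000 nM in this assay, at which 2 of the 3 values shown sit).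

Compound 4 `Nc1ccc(NC(=O)NCCCCC(c2ccc(F)cc2)c2ccc(F)cc2)cc1` has not yet been measured in this assay. It differs from compound 2 as follows: amino in place of iodo on an aromatic carbon. In words, this is amino in place of iodo on an aromatic carbon, para to a large group.

For the measured compounds named here, one measured step bears on this change, with methyl in place of iodo on an aromatic carbon: an at least 1.6-fold higher number from compound 2 to compound 3 (0.22 log units; that floor lies within the scatter). Going by these compounds, only a floor is known for that step, so its true size remains open. Compound 1 differs from compound 2 in more than one place and offers no direct guide. On this thin basis, no step beyond the scatter is expected, with a slight lean towards a higher number. The expected step is a 1.4-fold higher number from compound 2 to compound 4 (0.13 log units; within the scatter). A reading that returns only a limit is about as likely as a number. Compound 4 is estimated at 16000 nM (expected range 7000 nM to 40000 nM).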

Compound 4, half-maximal inhibitory concentration: > 20000 nM
Compound 4: a limit, no number (the forecaster's own chance of this, stated with the estimate: 50%); middle value at least 1.2-fold (0.09 log units) away from the limit.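

In this assay, amino in place of iodo on the aromatic carbon para to a large group gives an at least 1.6-fold higher number from compound 2 to compound 4 (0.22 log units; that floor lies within the scatter), the same floor as methyl in place of iodo, an at least 1.6-fold higher number from compound 2 to compound 3 (0.22 log units; that floor lies within the scatter). Two unlike replacements of iodo, one of them bringing a hydrogen-bond donor and acceptor that iodo lacks, therefore both end at a limit, but neither floor shows a step beyond the scatter, so no loss of activity on leaving iodo is established. The step between the methyl and amino compounds cannot be read, and the series now gives little resolution at this position: the limit of > 20000 nM in this assay, at which 3 of the 4 values shown sit.

Going by these compounds, the true size of both steps away from iodo remains open, as does whether iodo itself matters or any value near that of compound 2, 11800 nM, would be seen with another group at this position. Bromo, chloro or trifluoromethyl on this carbon would test this, while a carboxylic acid there or a shorter chain to the urea would show whether any other change moves the value clear of the limit.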